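Chloro for fluoro beside the trifluoromethyl group

A few compounds are considered here, and "the series" means these few. Any claim that something is new, unique, unknown or untested is made for them only; others in the source may bear on it.

Going by the values given here, compound 2 `COc1cc2c(cc1N1C[C@@H](C)N(C)[C@@H](C)C1)N(C(=O)Nc1cccc(C(F)(F)F)c1F)CC2` gives 158 nM in an assay on isolated protein for binding affinity to 5-hydroxytryptamine receptor 1D (Homo sapiens) (on this read-out higher numbers stand for weaker inhibition and lower numbers for stronger inhibition), the higher of the two numbers measured so far; its nearest neighbour is compound 1 `COc1cc2c(cc1N1C[C@@H](C)N(C)[C@@H](C)C1)N(C(=O)Nc1cccc(Cl)c1Cl)CC2`, which in this assay gives 79.4 nM, so the two stand within the scatter of each other. Compound 3 `COc1cc2c(cc1N1C[C@@H](C)N(C)[C@@H](C)C1)N(C(=O)Nc1cccc(C(F)(F)F)c1Cl)CC2` is not yet measured. It differs from compound 2 by chloro in place of fluoro on an aromatic carbon, ortho to a trifluoromethyl group. Among the compounds with values here, only one measured step bears on this change: a 2.0-fold higher number from compound 1 to compound 2 (0.30 log units; within the scatter), which swapped both halogens at once, and compound 3 sits between the two ends of that step, a chloro here and a trifluoromethyl there. Within the data shown here, with the single relevant step itself inside the scatter, no step beyond the scatter is expected in this assay from compound 2 to compound 3: the estimated step is a 1.4-fold lower number from compound 2 to compound 3 (0.16 log units; within the scatter). Compound 3 is expected to give about 110 nM, with a range from 45 nM to 270 nM.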

Compound 3, inhibition constant: 50.1 nM
The estimate for compound 3 lay 2.2-fold (0.34 log units) above the measured number; measured number inside the range.
By their numbers in this assay, from the lowest: compounds 3, 1 and 2 (each within the scatter of the next, the first and the last beyond it).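

In this assay, going by these compounds alone, the single change of chloro in place of fluoro on this aromatic carbon, ortho to a trifluoromethyl group, gives a 3.2-fold lower number from compound 2 to compound 3 (0.50 log units; beyond the scatter) and is the first step beyond the scatter. The earlier step changed both substituents at once, whereas here the halogen is separated from the other substituent. With chloro held on this carbon, trifluoromethyl in place of chloro on the other aromatic carbon gives a 1.6-fold lower number from compound 1 to compound 3 (0.20 log units; within the scatter) and stays within the scatter, so of these two single changes only the halogen change goes beyond it.

From the compounds shown here alone, how a bromo, methyl or methoxy group on this carbon would read stays open, as does whether the step holds when a nitrile replaces the trifluoromethyl group. No measurement at hand accounts for the step.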